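A few compounds are considered here, and "the series" means these few. Any claim that something is new, unique, unknown or untested is made for them only; others in the source may bear on it.

Compound 1 `COc1cc(/C=C/C(=O)C2=C(/C=C/c3ccc(O)c(OC)c3)NC(=O)NC2c2ccc(N(C)C)cc2)ccc1O` carries a 4-(dimethylamino)phenyl group on a saturated ring carbon of its core. In a functional assay, with a stated time of 20 min, tested at 50 uM (a higher number here means a stronger effect of the compound at the concentration tested, a lower number a weaker effect), compound 1 gives 89.2%. Compound 2 `COc1cc(/C=C/C(=O)C2=C(/C=C/c3ccc(O)c(OC)c3)NC(=O)NC2c2c(Cl)cccc2Cl)ccc1O` differs from compound 1 in one place: 2,6-dichlorophenyl in place of 4-(dimethylamino)phenyl on a saturated ring carbon. In this assay compound 2 gives 44.2%, so the exchange brought a number 45 percentage points lower from compound 1 to compound 2 (beyond the scatter).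

Compound 3 `COc1cc(/C=C/C(=O)C2=C(/C=C/c3ccc(O)c(OC)c3)NC(=S)NC2c2ccc(N(C)C)cc2)ccc1O` shares the 4-(dimethylamino)phenyl group with compound 1, but its core differs from the core of compound 1; the difference between the two cores is not broken down here. In this assay compound 3 gives 84%. That number lies within the scatter of the number of compound 1 and well beyond the scatter of the number of compound 2.

Compound 4 `COc1cc(/C=C/C(=O)C2=C(/C=C/c3ccc(O)c(OC)c3)NC(=S)NC2c2c(Cl)cccc2Cl)ccc1O` has not yet been measured in this assay. It differs from compound 3 in one place: 2,6-dichlorophenyl in place of 4-(dimethylamino)phenyl on a saturated ring carbon. The surroundings of the place are the same as in the change from compound 1 to compound 2, so this is the same change occurring a second time among these four compounds. Compound 3 stands where compound 1 stands, and the earlier exchange produced a number 45 percentage points lower from compound 1 to compound 2 (beyond the scatter). On that basis compound 4 is expected to show a step of a number 44 percentage points lower from compound 3 to compound 4 (beyond the scatter) in this assay. The estimate for compound 4 in this assay is 40%, with a likely range from 25% to 56%.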

Compound 4, a percentage reported as activity, at one concentration (the size of the read-out at that concentration, not a potency): 50%
The estimate for compound 4 lay 10 percentage points below the measured number; the measured number falls inside the stated range.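

In this assay the exchange of 4-(dimethylamino)phenyl for 2,6-dichlorophenyl on a saturated ring carbon brings a number 34 percentage points lower from compound 3 to compound 4 (beyond the scatter), so the change carries from the core of compound 1 to the core of compound 3 in direction and, within the scatter, in size: the same change on two cores in this assay, a number 45 percentage points lower (beyond the scatter) from compound 1 to compound 2 and a number 34 percentage points lower (beyond the scatter) from compound 3 to compound 4, 11 percentage points apart, within the scatter of two such steps

In this series, then, the earlier step was a fair guide to the later one, and the two cores cannot be told apart by how they respond to this exchange. Within the data shown here, this rests on only one pair of compounds per core, each read at a single concentration, so it gives no potency and does not show why the exchange lowers the number or that the step would hold on any further core.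

The compounds shown leave open how other groups on the saturated ring carbon, such as an unsubstituted phenyl, a pyridyl ring or a phenyl carrying a carboxylic acid, would read on either core. They also leave open whether the step survives when the 2-(4-hydroxy-3-methoxyphenyl)ethenyl group gives way to a simple alkyl chain or an amine.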